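From oxan-4-yl to oxan-3-yl on compound 1

The source may report more compounds than this note shows. Statements on the series, on what has been measured and on what is new or still open speak of the compounds shown alone.

Of the compounds shown here, three have been measured so far in a physicochemical assay for solubility, read by mass spectrometry, in phosphate buffer, with a stated time of 24 h, at pH 3; on this read-out lower numbers stand for lower solubility and higher numbers for higher solubility. Compound 1 (`O=C(Nc1ccc(OC(F)(F)F)cc1)NC1CCN(C(=O)C2CCOCC2)CC1`) gives 1300 ug/mL as the highest of the three numbers. Compound 3 (`O=C(Nc1ccc(OC(F)(F)F)c(F)c1)NC1CCN(C(=O)N2CCOCC2)CC1`) gives 294 ug/mL and compound 2 (`O=C(Nc1ccc(C(F)(F)F)cc1)NC1CCN(C(=O)C2=COCC2)CC1`) gives 8.2 ug/mL and both stand lower than compound 1 by more than the scatter. No two of these compounds differ in one place only, so no measured step bears directly on the next change.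

Compound 4 (`O=C(Nc1ccc(OC(F)(F)F)cc1)NC1CCN(C(=O)C2CCCOC2)CC1`) is still unmeasured. It carries oxan-3-yl in place of oxan-4-yl on a carbonyl carbon, and the change is oxan-3-yl in place of oxan-4-yl on a carbonyl carbon with the same atoms joined differently. Among the measured compounds shown here, the data hold no direct precedent for this swap, so the expectation in this assay is a small step or none beyond the scatter. For the measured compounds named here, a slight downward lean is expected because compound 1 at 1300 ug/mL is the top number so far. The expected step is a 1.3-fold lower number from compound 1 to compound 4 (0.11 log units; within the scatter) and it is likely to stay within the scatter. For compound 4 the estimated value is 1000 ug/mL with an expected range from 450 ug/mL to 2000 ug/mL around it.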

Compound 4, solubility: 868 ug/mL
Compound 4: the middle estimate sits 1.2-fold (0.06 log units) above what was measured; the range from low to high includes it.
By their numbers in this assay, from the lowest: compound 2; then compound 3; then compounds 4 and 1 (each within the scatter of the next).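

In this assay, among the compounds shown here, oxan-3-yl in place of oxan-4-yl on a carbonyl carbon gives the first step that can be read at a single place, and it comes out as a 1.5-fold lower number from compound 1 to compound 4 (0.18 log units; within the scatter). Between these two rings, with the rest of compound 1 unchanged, the read-out therefore does not separate the isomers, and a number of this height is not confined to oxan-4-yl, as compound 4 gives 868 ug/mL. Nothing measured in the compounds shown speaks to why the two rings read alike.

This single pair does not show how far that holds: oxan-2-yl, an amine-bearing ring or a carboxylic acid on the same carbonyl carbon could each read differently, and a longer chain in place of the ring would test whether a ring is needed here at all. For the compounds shown here, it also remains open whether the same swap would read alike on a different aryl end of the molecule, such as the one in compound 2, since the step rests on one background only.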